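The source may report more compounds than this note shows. Statements on the series, on what has been measured and on what is new or still open speak of the compounds shown alone.

Measured compounds:
- compound 1 `C=C[C@]1(C)C[C@@H](OC(=O)CNC(=O)Nc2cccc(Br)c2)[C@]2(C)[C@H](C)CC[C@]3(CCC(=O)[C@H]32)[C@@H](C)[C@@H]1O`: 3950 nM
- compound 2 `C=C[C@]1(C)C[C@@H](OC(=O)CNC(=O)NC(=O)c2cccc(F)c2)[C@]2(C)[C@H](C)CC[C@]3(CCC(=O)[C@H]32)[C@@H](C)[C@@H]1O`: > 10000 nM

Among the measured compounds shown here, in a functional assay on HGC-27 cells (Homo sapiens) for inhibition, read by MTT assay, with a stated time of 72 h (on this read-out higher numbers stand for weaker inhibition and lower numbers for stronger inhibition), compound 1 gives 3950 nM, the only true number so far. Compound 2 reads > 10000 nM, and this is a limit of the assay, not a number. the limit of > 10000 nM in this assay, at which 1 of the 2 values shown sits, is therefore the upper edge of what has been seen.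

The next compound to be tested is compound 3 `C=C[C@]1(C)C[C@@H](OC(=O)CNC(=O)Nc2ccccc2Br)[C@]2(C)[C@H](C)CC[C@]3(CCC(=O)[C@H]32)[C@@H](C)[C@@H]1O`. It keeps the core of compound 1 and the same atoms, joined differently: 2-bromophenyl in place of 3-bromophenyl on an amide-type nitrogen. In words, 2-bromophenyl takes the place of 3-bromophenyl on an amide-type nitrogen.

For the measured compounds named here, only one measured step bears on this, and only loosely. It touches the same place, yet an at least 2.5-fold higher number from compound 1 to compound 2 (0.40 log units; beyond the scatter) puts in a different group, (3-fluorophenyl)carbonyl, and so says little about moving the bromine. It does show that this assay can respond to changes at this place, so a wide range is warranted. No clear direction can be drawn from it, and no shift beyond the scatter is expected. The expected change is a 1.3-fold higher number from compound 1 to compound 3 (0.10 log units; within the scatter). For compound 3 the estimate is 5000 nM, with an expected range of 2000 nM to 10000 nM.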

Compound 3, half-maximal inhibitory concentration: > 10000 nM
Compound 3 was reported as a limit; the forecaster's own chance of this, stated with the estimate: 15%; middle value at least 2.0-fold (0.30 log units) from the limit.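

Moving the bromine is enough to change the result at this place, even though the atoms stay the same and only the way they are joined differs. In this assay, 2-bromophenyl in place of 3-bromophenyl on the amide-type nitrogen gives an at least 2.5-fold higher number from compound 1 to compound 3 (0.40 log units; beyond the scatter), which means weaker inhibition. The earlier step replaced the whole group, so it could not show this sensitivity to where the bromine sits on the phenyl ring, and the step between compound 2 and compound 3 cannot be read since both values are limits of the assay, not numbers: the limit of > 10000 nM in this assay, at which 2 of the 3 values shown sit.

As far as these compounds go, with a limit for compound 3, the true size of the loss stays unknown, and only compound 1 gives a number that later changes can be compared with. The compounds shown also leave open whether the bromine is needed at all, which an unsubstituted phenyl ring would test, and whether a chlorine or a methyl group in place of the bromine of 3-bromophenyl would keep or improve the inhibition seen with compound 1.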